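Swapping a Dichlorophenyl for a Dimethoxyphenyl Side Group

The compounds below may be only part of what the source reports. "The series", "measured", "known", "first", "only" and "open" are said of these compounds alone.

Compound 1 `Nc1cc(N)c2nc(-c3ccccc3)c(NCc3ccc(Cl)c(Cl)c3)nc2c1` — 69200 nM
Compound 2 `Nc1cc(N)c2nc(-c3ccccc3)c(Sc3ccc(Cl)c(Cl)c3)nc2c1` — < 100000 nM (a limit)
Compound 3 `CCOC(=O)[C@H](CCC(=O)O)NC(=O)c1ccc(Oc2nc3cc(N)cc(N)c3nc2-c2ccccc2)cc1` — < 100000 nM (a limit)

All three compounds were tested in a functional assay on NCI-H322M cells (Homo sapiens) for inhibition, read by sulforhodamine B assay, with a stated time of 48 h; a lower number here means that less compound is tolerated, a higher number that more compound is tolerated. Among the measured compounds shown here, compound 1 gives 69200 nM, and this is the only true number among the three. Compound 2 reaches only the limit < 100000 nM, which is a bound of the assay and not a number. Compound 3 likewise stops at the limit < 100000 nM. For the measured compounds named here, the whole picture is caught by the limit of < 100000 nM in this assay, at which 2 of the 3 values shown sit, so compound 1 stands alone as the one compound with a measured value.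

Compound 4 `COc1ccc(CNc2nc3cc(N)cc(N)c3nc2-c2ccccc2)cc1OC` has not yet been measured. It differs from compound 1 in one place: 3,4-dimethoxyphenyl in place of 3,4-dichlorophenyl on a saturated chain carbon bound to a nitrogen on an aromatic ring. Going by the values given here, no pair of measured compounds shows what such a swap does here, so there is no measured step to lean on. With only the value of compound 1 as an anchor, the change from compound 1 to compound 4 is expected to stay within the scatter, with no clear direction, as a 1.0-fold higher number from compound 1 to compound 4 (0.00 log units; within the scatter). Compound 4 is therefore expected to give about 70000 nM, somewhere between 30000 nM and 160000 nM.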

Compound 4, concentration lethal to 50% of the cells: 100000 nM
Beside the measured number, compound 4's estimate is 1.4-fold (0.15 log units) below it; the measured number falls inside the stated range.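

Replacing 3,4-dichlorophenyl with 3,4-dimethoxyphenyl on a saturated chain carbon bound to a nitrogen on an aromatic ring gives a 1.4-fold higher number from compound 1 to compound 4 (0.16 log units; within the scatter) in this assay. Among the compounds shown here, this is the first measured step at this position, and it shows that exchanging a group without hydrogen-bond acceptors for one that has them leaves no change that can be told from the usual spread of repeated measurements. The values also crowd at one end of what this assay reports, so it offers little room to tell these compounds apart: the limit of < 100000 nM in this assay, at which 2 of the 4 values shown sit.

Still open, as far as these compounds go, is whether an amine or a carboxylic acid on this ring, or a longer chain in place of the saturated chain carbon, would give a step beyond the scatter. Compound 2 offers no number for comparison, as its < 100000 nM is a limit.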